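A few compounds are considered here, and "the series" means these few. Any claim that something is new, unique, unknown or untested is made for them only; others in the source may bear on it.

Of the compounds shown here, two with the same core have been measured. Compound 1 `CCNC(=O)Nc1cc(=O)oc2cc(OCc3cccc(Cl)c3)ccc12` is the weaker of the pair: in an assay on brain (strain Sprague-Dawley) for inhibition of Amine oxidase [flavin-containing] B (Rattus norvegicus), read by spectrophotometry (a higher number here means a weaker inhibitor, a lower number a stronger inhibitor), compound 1 gives 31600 nM, the higher of the two numbers recorded so far. For the measured compounds named here, compound 2 `NC(=O)CCc1cc(=O)oc2cc(OCc3cccc(Cl)c3)ccc12` gives 15.1 nM in this assay, and the single step between them, a 2100-fold lower number from compound 1 to compound 2 (3.32 log units; beyond the scatter), shows how much the group attached to the core at that position matters.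

Compound 3 `NC(=O)CNc1cc(=O)oc2cc(OCc3cccc(Cl)c3)ccc12` has not been measured. It differs from compound 1 in one place: carbamoylmethyl in place of ethylcarbamoyl on a nitrogen on an aromatic ring. The nitrogen attached to the ring is kept, so compound 3 sits between compound 1 and compound 2 in its make-up; it shares with compound 2 a carbamoyl group carrying two hydrogens, while keeping the ring nitrogen of compound 1. Going by the values given here, the only step that bears on this change is the large one from compound 1 to compound 2, and since compound 3 only partly follows that change, a lower number than compound 1 is expected, but a less extreme one: the expected step is a 79-fold lower number from compound 1 to compound 3 (1.90 log units; beyond the scatter). Compound 3 is therefore estimated at 400 nM in this assay, within a range from 40 nM to 4000 nM.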

Compound 3, half-maximal inhibitory concentration: 49 nM
Compound 3: middle estimate off by 8.2-fold (0.91 log units), on the high side; low and high end bracket the measured number.
By their numbers in this assay, from the lowest: compound 2; then compound 3; then compound 1.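

The nitrogen on the aromatic ring is not enough on its own to explain the weakness of compound 1: with that nitrogen kept, putting carbamoylmethyl in place of ethylcarbamoyl gives a 640-fold lower number from compound 1 to compound 3 (2.81 log units; beyond the scatter) in this assay and restores most of the gap seen earlier. Swapping the (carbamoylmethyl)amino group of compound 3 for the 2-carbamoylethyl group of compound 2 is a far smaller matter, since the reverse change gives a 3.2-fold higher number from compound 2 to compound 3 (0.51 log units; beyond the scatter) and remains beyond the scatter, so what the nitrogen carries counts for much more here than whether the nitrogen is present. Nothing available gives a reason for either difference.

Ethylcarbamoyl and carbamoylmethyl differ both in the ethyl group and in how the chain is put together, so these compounds cannot show which of the two features matters more. They also leave open whether the carbamoyl group itself is needed, which a carboxylic acid or an amine at the end of the same chain would test, and how a longer chain on the nitrogen, such as 2-carbamoylethyl, would compare.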